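The source may hold more compounds than are shown below. What is called first, only, known or untested is meant among the compounds shown, and "the series" means these compounds.

Among the measured compounds shown here, in a functional assay on L1210 cells (Mus musculus) (a lower number here means a stronger inhibitor, a higher number a weaker inhibitor), only three compounds have been measured so far. Compound 1, `O=c1[nH]c(=O)n([C@H]2C[C@H](O)[C@@H](CO)O2)cc1C#CCCO`, gives a limit of the assay, > 1000 ug/mL. Compound 2, `CC#CCc1cn([C@H]2C[C@H](O)[C@@H](CO)O2)c(=O)[nH]c1=O`, likewise gives a limit, > 1000 ug/mL. For the measured compounds named here, compound 3, `O=c1[nH]c(=O)n([C@H]2C[C@H](O)[C@@H](CO)O2)cc1C#CCCCO`, is the one compound with a number: it gives 280 ug/mL, so it stands as the only readable value among the three, the other two sitting at the limit of > 1000 ug/mL in this assay, at which 2 of the 3 values shown sit. The step of an at least 3.5-fold lower number from compound 1 to compound 3 (0.55 log units; beyond the scatter) and the step of an at least 3.5-fold lower number from compound 2 to compound 3 (0.55 log units; beyond the scatter) both show that moving to 5-hydroxypent-1-yn-1-yl lowered the number by at least a modest amount.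

Compound 4, `CC(C)(C)C#Cc1cn([C@H]2C[C@H](O)[C@@H](CO)O2)c(=O)[nH]c1=O`, differs from compound 3 by tert-butyl in place of 3-hydroxypropyl on a triple-bonded carbon. Going by the values given here, none of the measured steps removes the hydroxy group; the two that bear on the same place only changed the length of the chain carrying it, so they give direction for lengthening rather than for its loss. The expectation therefore rests mainly on compound 3 alone, and the step of a 1.4-fold higher number from compound 3 to compound 4 (0.15 log units; within the scatter) is expected to stay within the scatter, with wide uncertainty on either side. Compound 4 is estimated at 400 ug/mL, between 120 ug/mL and 1500 ug/mL.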

Compound 4, concentration for 50% inhibition: 287 ug/mL
Compound 4: middle estimate off by 1.4-fold (0.14 log units), on the high side; low and high end bracket the measured number.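

In this assay, tert-butyl in place of 3-hydroxypropyl gives a 1.0-fold higher number from compound 3 to compound 4 (0.01 log units; within the scatter), so the hydroxy group at the end of the chain is not required for this level of inhibition: a group with no hydrogen-bond donor or acceptor serves equally well on the triple-bonded carbon. The new group also separates compound 4 from the two earlier compounds, with an at least 3.4-fold lower number from compound 2 to compound 4 (0.54 log units; beyond the scatter) and an at least 3.4-fold lower number from compound 1 to compound 4 (0.54 log units; beyond the scatter), and compound 1 carries a hydroxy group, so that group alone does not decide the result. Both of these sizes are only minimum values, because compound 1 and compound 2 each give a limit rather than a number: the limit of > 1000 ug/mL in this assay, at which 2 of the 4 values shown sit.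

From the compounds shown here alone, it remains open whether an amine or a carboxylic acid at the end of the chain would keep this level of inhibition. Among the compounds shown here, with only two readable values, it is also open how much lower the number could go with a longer chain at this position.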